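A few compounds are considered here, and "the series" means these few. Any claim that something is new, unique, unknown or untested is made for them only; others in the source may bear on it.

Measured compounds:
compound 1 `CC1(C)C=C(n2ccccc2=O)c2ccccc2O1` with 5.43 in a functional assay (aorta) with Rattus norvegicus as the target; on this read-out lower numbers stand for lower potency and higher numbers for higher potency (the scale is a negative logarithm)
compound 2 `CC1(C)C=C(n2ccccc2=O)c2cc(C=O)ccc2O1` with 6.91 in this assay

Compound 2 stands highest of the two numbers, owing to the step of a number 1.48 log units higher from compound 1 to compound 2 (beyond the scatter). Compound 3 `CC1(C)C=C(n2ccccc2=O)c2cc(C=C(C#N)C#N)ccc2O1` differs from compound 2 in one place: 2,2-dicyanoethenyl in place of formyl on an aromatic carbon. Going by the values given here, only the step from compound 1 to compound 2 bears on this change, and it shows that the formyl position can carry a substituent with a large gain; no measured step replaces the formyl itself. For compound 3 the expected step is a number 0.01 log units lower from compound 2 to compound 3 (within the scatter), within the scatter. Compound 3 is therefore estimated at 6.9, between 6 and 7.6.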

Compound 3, logarithm of the reciprocal of the active concentration, log(1/C): 6.95
The estimate for compound 3 lay 0.05 log units below the measured number; low and high end bracket the measured number.
By their numbers in this assay, from the lowest: compound 1; then compounds 2 and 3 (each within the scatter of the next).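

In this assay, 2,2-dicyanoethenyl in place of formyl gives a number 0.04 log units higher from compound 2 to compound 3 (within the scatter), so the read-out does not separate these two groups, although the new group is larger by heavy-atom count. The large gain also holds for this second group, with a number 1.52 log units higher from compound 1 to compound 3 (beyond the scatter), so the gain at this aromatic carbon is not confined to formyl. Nothing measured here accounts for the match between the two groups.

On these data alone, whether an amine, a hydroxyl or a longer alkyl chain on this aromatic carbon would keep that level remains open.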